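This account rests on a few compounds, and the source may have more. Where it says the series, first, only, none or still open, it means among the compounds named here.

Among the compounds with values here, of the two numbers so far in a functional assay for inhibition of sodium/hydrogen exchanger (Oryctolagus cuniculus) (on this read-out higher numbers stand for weaker inhibition and lower numbers for stronger inhibition), compound 2 `Cc1cc(C2CCCCC2)c(S(C)(=O)=O)cc1C(=O)N=C(N)N` gives the higher one, 22 nM; the nearest is compound 1 `Cc1cc(Br)c(S(C)(=O)=O)cc1C(=O)N=C(N)N`, which in this assay gives 12 nM, a gap that is within the scatter. Compound 3 `Cc1cc(-c2ccc(Cl)cc2Cl)c(S(C)(=O)=O)cc1C(=O)N=C(N)N` is not yet measured. It differs from compound 2 by 2,4-dichlorophenyl in place of cyclohexyl on an aromatic carbon. Within the data shown here, the only measured step at this place is a 1.8-fold higher number from compound 1 to compound 2 (0.26 log units; within the scatter). It bears on the present change in that it also exchanged the group on the same aromatic carbon, but neither compound 1 nor compound 2 carries an aromatic ring there, so the series gives no direct reading on a 2,4-dichlorophenyl group in this position. Because that step was a 1.8-fold higher number from compound 1 to compound 2 (0.26 log units; within the scatter), the group at this carbon has so far moved the number little, and a step of no more than the scatter, in either direction, is expected in this assay. The expected step from compound 2 to compound 3 is a 1.1-fold higher number from compound 2 to compound 3 (0.06 log units; within the scatter). Compound 3 is estimated to give about 25 nM in this assay, with a range from 8 nM to 80 nM.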

Compound 3, half-maximal inhibitory concentration: 42 nM
The estimate for compound 3 lay 1.7-fold (0.23 log units) below the measured number, and the stated range covers the measured number.
By their numbers in this assay, from the lowest: compounds 1, 2 and 3 (each within the scatter of the next, the first and the last beyond it).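

Within the data shown here, compound 3 carries an aromatic ring on this carbon, which the earlier compounds lack, yet in this assay the exchange of cyclohexyl for 2,4-dichlorophenyl gives a 1.9-fold higher number from compound 2 to compound 3 (0.28 log units; within the scatter) and so does not separate these two six-membered rings. Among these compounds, measured against bromo, the same group gives a 3.5-fold higher number from compound 1 to compound 3 (0.54 log units; beyond the scatter) as the only step beyond the scatter, and a modest one, so a group of 8 heavy atoms on this carbon, ortho to the methylsulfonyl group, costs little in this read-out, while compound 2 stands within the scatter of both compound 1 and compound 3. Nothing available explains these steps.

Unsubstituted phenyl would show whether the two chlorine atoms contribute anything to the number for compound 3, and the 2,4-dichlorophenyl pattern cannot be separated from the aromatic ring itself on the present compounds. Also open is how this carbon responds to groups of another kind, such as an amine, a carboxylic acid or a longer alkyl chain, since all three groups shown carry no hydrogen-bond donors or acceptors and no net charge.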